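The source may hold more compounds than are shown below. What is called first, only, known or untested is meant among the compounds shown, and "the series" means these compounds.

Working notes on the series. In a functional assay on HL-60 cells (Homo sapiens) for inhibition, read by MTT assay, with a stated time of 48 h, tested at 10 uM (on this read-out higher numbers stand for more inhibition of growth at the one concentration tested and lower numbers for less inhibition of growth), compound 2 `COc1ccccc1/C=N/NC(=O)c1ccc(-c2ccc(F)cc2F)o1` gives 27.4%, the higher of the two numbers gathered so far. Compound 1 `O=C(N/N=C/c1ccccc1O)c1ccc(-c2ccc(F)cc2)o1` gives 13.1% in this assay; the two compounds differ in more than one place, so the gap between them is not attributed to any single change, and the two values are simply noted as they stand.

The next compound keeps the difluorophenyl end of compound 2 and changes only the other end: hydrogen in place of methyl on an oxygen on an aromatic ring, giving compound 3 `O=C(N/N=C/c1ccccc1O)c1ccc(-c2ccc(F)cc2F)o1`. Among the measured compounds shown here, no pair of measured compounds differing in this one place exists here, so the size of the step is not known from the data; a small step downward, or none beyond the scatter, is expected. For compound 3 the expected step from compound 2 is a number 7.4 percentage points lower from compound 2 to compound 3 (within the scatter). Compound 3 is thus estimated at 20% in this assay, with a range of 8% to 32%.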

Compound 3, percent growth inhibition at one concentration: 43.1%
Estimate against measurement, compound 3: 23.1 percentage points below, outside the stated range (above it).
By their numbers in this assay, from the lowest: compound 1; then compound 2; then compound 3.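

In this assay, 2-hydroxyphenyl in place of 2-methoxyphenyl with the difluorophenyl end held fixed gives a number 15.7 percentage points higher from compound 2 to compound 3 (beyond the scatter) and shows that this oxygen on an aromatic ring is a position where hydrogen in place of methyl raises growth inhibition. With the 2-hydroxyphenyl end held fixed, fluoro in place of hydrogen on an aromatic carbon gives a number 30 percentage points higher from compound 1 to compound 3 (beyond the scatter) and so also raises growth inhibition, which means both single changes leading to compound 3 point the same way. Nothing measured here bears on what lies behind either step.

On these data alone, whether methoxy to hydroxy gives a step of similar size with the aromatic end of compound 1 remains open. Also open, as far as these compounds go, is how an amine or a carboxylic acid would read in place of the hydroxy group on that ring.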